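This account rests on a few compounds, and the source may have more. Where it says the series, first, only, none or still open, it means among the compounds named here.

Cytotoxicity notes on the amide series. Compound 1 `CS(=O)(=O)Nc1ccc(NC(=O)c2cc(C(F)(F)F)cc(C(F)(F)F)c2)cc1Cl` gives 185000 nM in an ADME assay on HEK293 cells (Homo sapiens) for cytotoxicity, read by MTT assay, with a stated time of 48 h; on this read-out higher numbers stand for weaker inhibition and lower numbers for stronger inhibition. Compound 2 `CCS(=O)(=O)Nc1ccc(NC(=O)c2cc(C(F)(F)F)cc(C(F)(F)F)c2)cc1Cl` carries the change methyl in place of hydrogen on a saturated chain carbon bound to a sulfonyl sulfur and gives 32200 nM in this assay, the step being a 5.7-fold lower number from compound 1 to compound 2 (0.76 log units; beyond the scatter). Compound 3 `CS(=O)(=O)Nc1ccc(NC(=O)c2ccc(Cl)cc2)cc1F` belongs to a different core; the difference between the two cores is not broken down here. Compound 3 gives 216000 nM in this assay, which sits within the scatter of compound 1 and well apart from compound 2.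

Compound 4 `CCS(=O)(=O)Nc1ccc(NC(=O)c2ccc(Cl)cc2)cc1F` is the unmeasured partner of compound 3 and carries the change (methyl in place of hydrogen on a saturated chain carbon bound to a sulfonyl sulfur), the same change at the same place as that made from compound 1 to compound 2. The only measured occurrence of this change, from compound 1 to compound 2, is taken as the guide; the step from compound 3 to compound 4 is expected to be of comparable size, namely a 5.7-fold lower number from compound 3 to compound 4 (0.75 log units; beyond the scatter), because the value of compound 3 at 216000 nM sits so close to that of compound 1. Compound 4 is thus estimated at 38000 nM, with a range from 13000 nM to 110000 nM.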

Compound 4, half-maximal inhibitory concentration: 53400 nM
Estimate against measurement, compound 4: 1.4-fold (0.15 log units) below, within the range that was stated.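

In this assay the change from methylsulfonyl to ethylsulfonyl again goes with a lower number, with a 4.0-fold lower number from compound 3 to compound 4 (0.61 log units; beyond the scatter). Set beside the earlier step, the change carries over from the core of compound 1 to the core of compound 3 with no separable difference in size: the same change on two cores in this assay, a 5.7-fold lower number (0.76 log units; beyond the scatter) from compound 1 to compound 2 and a 4.0-fold lower number (0.61 log units; beyond the scatter) from compound 3 to compound 4, 1.4-fold (0.15 log units) apart, within the scatter of two such steps. This is a match between two pairs in a single assay, so it supports carrying the step between these two cores only; it does not show that the step would hold on any other core, and it says nothing about what lies behind the lower numbers.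

The compounds shown leave open whether a longer chain such as propyl, or a branched one such as isopropyl, in the same place would extend the step or end it. Also open, on these data alone, is what an amine or a carboxylic acid at the end of that chain would do to the number on either core.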